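Isopropyl for phenyl on the isoxazole-type core of compound 2

The source may report more compounds than this note shows. Statements on the series, on what has been measured and on what is new or still open speak of the compounds shown alone.

Measured so far in an assay on isolated protein for agonist activity at sphingosine 1-phosphate receptor 2 (Homo sapiens); on this read-out lower numbers stand for an effect already at smaller amounts and higher numbers for an effect only at larger amounts of compound:
Compound 1, `CC1CCCCC1N(C(=O)c1cc(C2CC2)on1)C1CCCCC1`, gives > 50000 nM, a limit of the assay.
Compound 2, `O=C(c1cc(-c2ccccc2)on1)N(C1CCCCC1)C1CCCCC1`, gives > 50000 nM, a limit of the assay.
Compound 3, `CC1CCCCC1N(C(=O)c1cc(C2CC2)on1)C1CCCCCC1`, gives > 50000 nM, a limit of the assay.

Compound 2 thus stands at a limit, and the two other values shown stand at the same limit; the limit of > 50000 nM in this assay, at which 3 of the 3 values shown sit, describes this situation. Going by the values given here, the one step between measured compounds, a step that the two limits leave unreadable from compound 1 to compound 3, cannot be read, since both of its ends are limits. Among the compounds with values here, no measured step therefore bears on the change now in question.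

Compound 4, `CC(C)c1cc(C(=O)N(C2CCCCC2)C2CCCCC2)no1`, differs from compound 2 in one place: isopropyl in place of phenyl on an aromatic carbon. With every measured value sitting at the limit and no readable step to guide the expectation, the most that can be said is that compound 4 is expected to remain at or near that limit, so the expected step of a number no higher from compound 2 to compound 4 (the limit leaves the size open) from compound 2 to compound 4 is none beyond the scatter. Compound 4 is therefore estimated at 50000 nM in this assay, in a range from 15000 nM to 200000 nM, most likely again reported only as a limit.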

Compound 4, half-maximal effective concentration: > 50000 nM
Compound 4 ended at the assay's limit; the forecaster's own chance of this, stated with the estimate: 85%; the middle value sits exactly at the limit.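

The step from compound 2 to compound 4 cannot be read, since both ends are limits of this assay and not numbers. Whether any of these changes alters activity, and how the compounds rank against one another, stays open: the limit of > 50000 nM in this assay, at which 4 of the 4 values shown sit.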